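One Methoxy Step, Seen Once and Expected Again

The source may hold more compounds than are shown below. What is called first, only, known or untested is meant among the compounds shown, and "the series" means these compounds.

Measured in a functional assay on COLO 205 cells (Homo sapiens) for inhibition, read by sulforhodamine B assay, with a stated time of 48 h; a lower number here means a stronger inhibitor of growth, a higher number a weaker inhibitor of growth:
- compound 1, `COc1cc(-c2cc(/C=C/C(=O)c3ccc(N)cc3)[nH]n2)cc(OC)c1OC`, gives 3340 nM
- compound 2, `COc1ccc(C(=O)/C=C/c2cc(-c3cc(OC)c(OC)c(OC)c3)n[nH]2)cc1OC`, gives 3210 nM
- compound 3, `COc1ccc(-c2cc(/C=C/C(=O)c3ccc(N)cc3)[nH]n2)cc1OC`, gives 3590 nM

Among the measured compounds shown here, the three numbers sit close together; none of the steps between them is beyond the usual scatter, so no compound among them can be called the strongest or the weakest. Going from compound 3 to compound 1 the change is methoxy in place of hydrogen on an aromatic carbon, and it made a 1.1-fold lower number from compound 3 to compound 1 (0.03 log units; within the scatter). Compound 1 and compound 2 differ by 3,4-dimethoxyphenyl in place of 4-aminophenyl on a carbonyl carbon, with a 1.0-fold lower number from compound 1 to compound 2 (0.02 log units; within the scatter). The difference between the cores of compound 2 and compound 3 is not broken down here; their two values simply lie within the scatter of each other.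

Compound 4, `COc1cc(C(=O)/C=C/c2cc(-c3cc(OC)c(OC)c(OC)c3)n[nH]2)cc(OC)c1OC`, has not been measured. It stands to compound 2 as compound 1 stands to compound 3: the change is methoxy in place of hydrogen on an aromatic carbon, and the surroundings of the place are the same in both cases, so this is the same change, occurring twice among the compounds shown.

In this assay, for the measured compounds named here, the step from compound 2 to compound 4 is therefore expected to be about a 1.1-fold lower number from compound 2 to compound 4 (0.03 log units; within the scatter), because the only earlier instance of this change gave a 1.1-fold lower number from compound 3 to compound 1 (0.03 log units; within the scatter), a step within the scatter. Compound 4 is accordingly estimated at 3000 nM, with a likely range from 1500 nM to 6500 nM.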

Compound 4, concentration for total growth inhibition: 3130 nM
For compound 4 the middle estimate is 1.0-fold (0.02 log units) below the measured one; the measured number falls inside the stated range.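

In this assay the second instance of methoxy in place of hydrogen, on the core of compound 2, gave a 1.0-fold lower number from compound 2 to compound 4 (0.01 log units; within the scatter) and so stayed within the scatter, as the first instance had. Carried from one core to the other, the change therefore gave the same result on both, with no difference between the two steps that the data can resolve: the same change on two cores in this assay, a 1.1-fold lower number (0.03 log units; within the scatter) from compound 3 to compound 1 and a 1.0-fold lower number (0.01 log units; within the scatter) from compound 2 to compound 4, 1.0-fold (0.02 log units) apart, within the scatter of two such steps. Among the compounds shown here, this does not show that methoxy at this place has an effect that transfers, since neither step can be told apart from no step at all; the agreement rests on two small steps on two cores and says nothing about other cores, or about a larger effect being carried across.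

What the compounds shown leave open is whether a group other than methoxy in the same place, such as a hydroxyl, an ethoxy or a longer alkoxy chain, or a chlorine atom, would give a step beyond the scatter. Going by these compounds, it is also open whether methoxy in place of hydrogen would stay this small on a core that carries a carboxylic acid where compound 1 has its 4-aminophenyl.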